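The source may hold more compounds than are shown below. What is called first, only, known or untested is meant among the compounds shown, and "the series" means these compounds.

Compound 1 `O=C(O)[C@@H]1NC[C@@H](O)[C@@H](O)[C@H]1O` is the starting point here. In an assay on isolated protein for inhibition of cytosolic endo-beta-N-acetylglucosaminidase (Homo sapiens), tested at 1000 uM (on this read-out lower numbers stand for less inhibition and higher numbers for more inhibition at the one concentration tested (going by the name of the read-out)), compound 1 gives 26%, the lower of the two numbers recorded so far. For the measured compounds named here, its only measured neighbour is compound 2 `O=C(O)[C@@H]1NC[C@H](O)[C@@H](O)[C@H]1O`, which in this assay gives 42%. The step between them is a number 16 percentage points higher from compound 1 to compound 2 (beyond the scatter), and what underlies it is the fact that compounds 1 and 2 differ only in the configuration as drawn, a single ring carbon drawn in the opposite configuration.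

The compound to be examined next is compound 3 `O=C(O)[C@@H]1NC[C@@H](O)[C@H](O)[C@H]1O`. Relative to compound 1 it changes in this way: the two compounds have the same atoms and bonds and differ only in configuration as drawn: 1 of 4 stereo elements differ; a stereocentre at a saturated ring carbon is drawn R in compound 1 and S in compound 3. Going by the values given here, this is again a flip at one ring carbon, though not the same carbon as in compound 2, so the step from compound 1 to compound 2 is the only measured step that bears on it, and that step was modest. A flip at a different centre need not move the number the same way, so a modest change in either direction, or none beyond the scatter, is plausible. Compound 3 is therefore expected to give 35% in this assay, somewhere between 10% and 65%. That amounts to an expected step of a number 9 percentage points higher from compound 1 to compound 3 (within the scatter).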

Compound 3, a percentage reported as inhibition, at one concentration (the size of the read-out at that concentration, not a potency): 50%
For compound 3 the middle estimate is 15 percentage points below the measured one; low and high end bracket the measured number.
By their numbers in this assay, from the lowest: compound 1; then compounds 2 and 3 (each within the scatter of the next).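

For the compounds shown here, the result shows that a second ring carbon of compound 1, not the one flipped in compound 2, also responds to inversion in this assay, with a number 24 percentage points higher from compound 1 to compound 3 (beyond the scatter). No atom or bond changes in this step, so the shift can be traced to configuration alone: the fact that compounds 1 and 3 differ only in the configuration as drawn

Two separate single flips of compound 1 therefore both raise the number, while the comparison of the two flipped compounds, which differ at two ring carbons, gives a number 8 percentage points higher from compound 2 to compound 3 (within the scatter), so no order can be set between them.

On these data alone, what stays open is whether the two flips add up when combined in one compound, and how the remaining stereocentres of the shared core behave when inverted. Also open, as far as these compounds go, is what would happen if the carboxylic acid were replaced by an amide or a hydroxymethyl group, or if a longer chain were attached to the amine of the core.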